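Compound 1 to compound 4: one group exchanged

The source may hold more compounds than are shown below. What is called first, only, known or untested is meant among the compounds shown, and "the series" means these compounds.

Measured in a functional assay on KB cells (Homo sapiens) for cytotoxicity; on this read-out lower numbers stand for an effect already at smaller amounts and higher numbers for an effect only at larger amounts of compound:
compound 1 `Cn1cncc1/C=N/Nc1ccnc2cc(Cl)ccc12` gives 73.8 uM
compound 2 `Oc1cc(/C=N/Nc2ccnc3cc(Cl)ccc23)ccc1CN1CCCC1` gives 152 uM
compound 3 `FC(F)(F)c1ccc(-c2n[nH]cc2/C=N/Nc2ccnc3cc(Cl)ccc23)cc1` gives 1.2 uM

Compound 1 stands in the middle of these three numbers, lower than compound 2 and far higher than compound 3. Compound 4 `Cc1noc(C)c1/C=N/Nc1ccnc2cc(Cl)ccc12` has not yet been measured. It carries 3,5-dimethyl-1,2-oxazol-4-yl in place of 1-methyl-1H-imidazol-5-yl on a carbon with a double bond to nitrogen. Among the compounds with values here, no measured pair shows this exchange alone, so the guidance is thin. Compound 3 reaches 1.2 uM with another group on that same carbon, so a modest move toward a lower number in this assay is expected. The expected change is a 2.1-fold lower number from compound 1 to compound 4 (0.32 log units; beyond the scatter). For compound 4 the estimated value is 35 uM, with an expected range from 9 uM to 120 uM.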

Compound 4, concentration for half-maximal effect: 171 uM
The estimate for compound 4 lay 4.9-fold (0.69 log units) below the measured number, and the stated range ends below it.
By their numbers in this assay, from the lowest: compound 3; then compound 1; then compounds 2 and 4 (each within the scatter of the next).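

Putting 3,5-dimethyl-1,2-oxazol-4-yl in place of 1-methyl-1H-imidazol-5-yl on a carbon with a double bond to nitrogen gives, in this assay, a 2.3-fold higher number from compound 1 to compound 4 (0.36 log units; beyond the scatter), so this exchange does not lower the number. Both groups have the same counts of hydrogen-bond donors and acceptors and no net charge, so those counts do not account for the step. Nothing available explains the step. On these data alone, it remains open whether the two methyl groups matter, which the unmethylated 1,2-oxazol-4-yl group could test. As far as these compounds go, how an unsubstituted phenyl group on that carbon would read in this assay also remains open.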